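The compounds below may be only part of what the source reports. "The series", "measured", "known", "first", "only" and "open" are said of these compounds alone.

Three compounds have been measured in a functional assay on BGC-823 cells (Homo sapiens) for cytotoxicity, read by MTT assay; a lower number here means a stronger inhibitor, a higher number a weaker inhibitor:

Compound 1, `Cc1cccc(Nc2nc(C)c(C(=O)/C=C/c3ccccc3Cl)s2)c1`: in this assay compound 1 gives 24200 nM.
Compound 2, `Cc1ccccc1Nc1nc(C)c(C(=O)/C=C/c2ccc(Cl)cc2)s1`: in this assay compound 2 reaches only a limit of the assay, > 25000 nM.
Compound 3, `Cc1ccc(Nc2nc(C)c(C(=O)/C=C/c3ccc(Cl)cc3)s2)cc1`: in this assay compound 3 likewise reaches only a limit of the assay, > 25000 nM.

All three share one core and differ only in the methylphenyl group on the nitrogen and in the chlorophenyl group at the other end. Compound 3 therefore stands at the ceiling of what the assay reports, and the whole picture is shaped by the limit of > 25000 nM in this assay, at which 2 of the 3 values shown sit. Among the measured compounds shown here, the single one-point step among the measured compounds, a step that the two limits leave unreadable from compound 2 to compound 3, is unreadable for that reason.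

Compound 4, `Cc1cccc(Nc2nc(C)c(C(=O)/C=C/c3ccc(Cl)cc3)s2)c1`, is the next compound. The change is 3-methylphenyl in place of 4-methylphenyl on a nitrogen on an aromatic ring. For the measured compounds named here, no measured step speaks to moving a methyl group on a 4-chlorophenyl-bearing core, and the one step that exists is blind. Compound 1 carries the same 3-methylphenyl group, though with a 2-chlorophenyl group, and in this assay compound 1 gives 24200 nM, a weak inhibitor. The expectation for compound 4 is therefore no step beyond the scatter, a step that the limit leaves unreadable from compound 3 to compound 4. Compound 4 is estimated at 30000 nM, with a range from 15000 nM to 80000 nM.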

Compound 4, half-maximal inhibitory concentration: > 25000 nM
Compound 4: only a limit was reported; the forecaster's own chance of this, stated with the estimate: 60%; the middle value is on the limit's open side.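

With 2-methylphenyl, 3-methylphenyl and 4-methylphenyl on the nitrogen, compound 2, compound 3 and compound 4 all end in a limit of this assay rather than a number, so the steps among them cannot be read: the limit of > 25000 nM in this assay, at which 3 of the 4 values shown sit.

Among the compounds shown here, the one readable step keeps the 3-methylphenyl group and puts 4-chlorophenyl in place of 2-chlorophenyl: an at least 1.0-fold higher number from compound 1 to compound 4 (0.01 log units; that floor lies within the scatter). It gives no sign of a stronger inhibitor from this change, and its true size stays hidden.

On these data alone, it remains open whether an amine or a carboxylic acid on that phenyl ring, in place of the methyl group, would bring a 4-chlorophenyl compound to a readable number. As far as these compounds go, it is also open whether 2-chlorophenyl paired with 2-methylphenyl or 4-methylphenyl would give a readable number.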